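A few compounds are considered here, and "the series" means these few. Any claim that something is new, unique, unknown or untested is made for them only; others in the source may bear on it.

Measured so far:
Compound 1 `COC(OC)C1OC(C)(C)OC1Cc1cnc2ccccc2n1` gives > 100 ug/mL in a functional assay on EC9706 cells (Homo sapiens) for cytotoxicity, read by MTT assay, with a stated time of 48 h (a lower number here means a stronger inhibitor, a higher number a weaker inhibitor), which is a limit of the assay and not a number.
Compound 2 `COC(OC)C1OC(C)(C)OC1Cc1cnc2cc(Cl)ccc2n1` gives 30.5 ug/mL in this assay.
Compound 3 `COC(OC)C1OC(C)(C)OC1Cc1cnc2ccc(Cl)cc2n1` gives 30.5 ug/mL in this assay.

Compound 1 stands at the limit of > 100 ug/mL in this assay, at which 1 of the 3 values shown sits, so only a limit is known for it; compounds 2 and 3 sit within the scatter of each other. The two measured steps, an at least 3.2-fold lower number from compound 1 to compound 2 (0.51 log units; beyond the scatter) and an at least 3.2-fold lower number from compound 1 to compound 3 (0.51 log units; beyond the scatter), both come from a single substituent on the same carbon-only ring of the shared core.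

Compound 4 `COC(OC)C1OC(C)(C)OC1Cc1cnc2cc(C(=O)c3ccccc3)ccc2n1` differs from compound 1 by benzoyl in place of hydrogen on an aromatic carbon. The measured steps from compound 1 bear on it in that they too put a group on that ring in place of hydrogen, and both moved the number down by at least a modest amount. On these data alone, a step of similar direction is therefore expected in this assay, toward a lower number, though its size with a benzoyl group rather than chloro is untested. Compound 4 is expected to give 35 ug/mL, with a range of 10 ug/mL to 100 ug/mL. The expected step is an at least 2.8-fold lower number from compound 1 to compound 4 (0.45 log units; beyond the scatter).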

Compound 4, half-maximal inhibitory concentration: 80 ug/mL
Compound 4: the middle estimate sits 2.3-fold (0.36 log units) below what was measured; the range from low to high includes it.
By their numbers in this assay, from the lowest: compounds 2 and 3 (each within the scatter of the next); then compound 4. At a limit, above all of these: compound 1.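

Benzoyl in place of chloro on this aromatic carbon gives a 2.6-fold higher number from compound 2 to compound 4 (0.42 log units; beyond the scatter) in this assay, so the lower number seen with chloro does not carry over to every group placed there. Benzoyl in place of hydrogen gives an at least 1.2-fold lower number from compound 1 to compound 4 (0.09 log units; that floor lies within the scatter), so a real drop from hydrogen is shown for chloro but not established for benzoyl. Compound 1 is held at a limit and not a number, so that floor cannot be sharpened: the limit of > 100 ug/mL in this assay, at which 1 of the 4 values shown sits.

On these data alone, whether fluoro, methoxy or an amine on this carbon would sit with chloro or with benzoyl remains open. Also open, as far as these compounds go, is how benzoyl behaves on the carbon that carries chloro in compound 3.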